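Swapping an Amino Chain for an Ether Chain

This account rests on a few compounds, and the source may have more. Where it says the series, first, only, none or still open, it means among the compounds named here.

Compound 3 `COCCNc1nc(C)nc2c1nnn2-c1ccc(C(C)C)cc1Br` gives 242 nM in an in vitro assay on 293-EBNA cells for binding affinity to corticotropin-releasing factor receptor 1 (Homo sapiens) (a higher number here means a weaker inhibitor, a lower number a stronger inhibitor), the largest of the three numbers shown, though its gap to compound 2 lies within the scatter. Compound 2 `CCN(c1nc(C)nc2c1nnn2-c1ccc(C(C)C)cc1Br)C(COC)COC` gives 123 nM, and a 2.0-fold higher number from compound 2 to compound 3 (0.29 log units; within the scatter). Compound 1 `COCC(COC)N(C)c1nc(C)nc2c1nnn2-c1ccc(C(C)C)cc1Br` gives 21.3 nM, and an 11-fold higher number from compound 1 to compound 3 (1.06 log units; beyond the scatter). Compound 4 `CCOCC(COCC)Oc1nc(C)nc2c1nnn2-c1ccc(C(C)C)cc1Br` differs from compound 3 in one place: a group of 10 heavy atoms (7 carbon, 3 oxygen; no ring) in place of a group of 5 heavy atoms (3 carbon, 1 nitrogen, 1 oxygen; no ring), on an aromatic carbon. Both measured steps bear on this, since each also exchanges a small group for a larger one on the same aromatic carbon, and read in reverse both larger groups gave lower numbers. The entering group in compound 4 is larger still, yet it carries no hydrogen-bond donor, a feature without any measured counterpart here. A modest lowering is therefore expected, a 2.0-fold lower number from compound 3 to compound 4 (0.30 log units; within the scatter), with wide uncertainty. Compound 4 is estimated at 120 nM in this assay, between 35 nM and 400 nM.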

Compound 4, inhibition constant: 39.7 nM
Estimate against measurement, compound 4: 3.0-fold (0.48 log units) above; the measured number falls inside the stated range.
By their numbers in this assay, from the lowest: compounds 1 and 4 (each within the scatter of the next); then compounds 2 and 3 (each within the scatter of the next).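

Putting the larger chain of compound 4 in place of (2-methoxyethyl)amino on this aromatic carbon gives more than the opening trend suggested (a 6.1-fold lower number from compound 3 to compound 4 (0.79 log units; beyond the scatter)), and the chain without nitrogen also separates from compound 2 (a 3.1-fold lower number from compound 2 to compound 4 (0.49 log units; beyond the scatter)). Against compound 1, the change stays within the scatter (a 1.9-fold higher number from compound 1 to compound 4 (0.27 log units; within the scatter)), so a nitrogen link is not required here for a number in this range. No measurement shown accounts for these steps.

Going by these compounds, compound 4 differs from compound 1 in both its linking atom and its chain ends, so the contribution of each remains open. An oxygen-linked chain with methoxy ends, or a sulfur-linked one, could separate them.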